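This account rests on a few compounds, and the source may have more. Where it says the series, first, only, none or still open, it means among the compounds named here.

Working notes on the series.

Of the compounds shown here, three share one core and have been measured in an assay on membranes from CHO cells for displacement of a labelled ligand from adenosine receptor A1 (Homo sapiens), read by scintillation counting, with a stated time of 60 min, tested at 1 uM; on this read-out higher numbers stand for more inhibition at the one concentration tested (going by the name of the read-out) and lower numbers for less inhibition. Compound 1 `CC1=C(C(=O)OC2CCCCC2)C(c2ccco2)NC(=O)N1` gives 1% in this assay. Compound 2 `CC1=C(C(=O)OCC2CC2)C(c2ccco2)NC(=O)N1` gives 29% in this assay. Compound 3 `CC1=C(C(=O)OC2CCCCC2)C(c2ccoc2)NC(=O)N1` gives 15% in this assay. Compound 2 and compound 3 thus both stand above compound 1, and the two measured steps are small but beyond the scatter.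

The first step, a number 28 percentage points higher from compound 1 to compound 2 (beyond the scatter), goes with the change (cyclopropylmethyl in place of cyclohexyl on an oxygen next to a carbonyl group). The second step, a number 14 percentage points higher from compound 1 to compound 3 (beyond the scatter), goes with the change (furan-3-yl in place of furan-2-yl on a saturated ring carbon), in which the same atoms are joined differently.

Compound 4 `CC1=C(C(=O)OCC2CC2)C(c2ccoc2)NC(=O)N1` has not yet been measured in this assay. It carries the change (cyclopropylmethyl in place of cyclohexyl on an oxygen next to a carbonyl group), which is the same change, at the same place, that separates compound 1 from compound 2; the two cores on which it is made differ by furan-3-yl in place of furan-2-yl on a saturated ring carbon. Among the compounds shown, this change occurs twice in all.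

For compound 4 the step of a number 25 percentage points higher from compound 3 to compound 4 (beyond the scatter) is expected, of about the size seen once already in a number 28 percentage points higher from compound 1 to compound 2 (beyond the scatter), on the assumption that the change acts alike on both cores; a single earlier case at one concentration is a thin basis, so the range is kept wide. The estimate for compound 4 in this assay is 40%, between 20% and 62%.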

Compound 4, a percentage reported as inhibition, at one concentration (the size of the read-out at that concentration, not a potency): 29%
Compound 4: middle estimate off by 11 percentage points, on the high side; measured number inside the range.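

The change to cyclopropylmethyl in place of cyclohexyl again goes with a higher number in this assay, a number 14 percentage points higher from compound 3 to compound 4 (beyond the scatter), and its size on the two cores does not differ beyond what repeated measurements would allow: the same change on two cores in this assay, a number 28 percentage points higher (beyond the scatter) from compound 1 to compound 2 and a number 14 percentage points higher (beyond the scatter) from compound 3 to compound 4, 14 percentage points apart, within the scatter of two such steps

The change to furan-3-yl in place of furan-2-yl reads no change at the digits printed from compound 2 to compound 4 (within the scatter), and even this step cannot be told apart from its earlier counterpart: the same change on two cores in this assay, a number 14 percentage points higher (beyond the scatter) from compound 1 to compound 3 and no change at the digits printed (within the scatter) from compound 2 to compound 4, 14 percentage points apart, within the scatter of two such steps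

So the two pairs are compatible with each change carrying from one core to the other, but with only two cases per change, each read at one concentration, they do not show that the steps are equal or that either change would hold on a further core.

The compounds shown leave open whether the same step would appear with other groups on the oxygen next to the carbonyl group, such as a straight butyl chain or a benzyl group, or with a phenyl or thiophen-2-yl group on the saturated ring carbon. They also leave open what potencies lie behind these percentages, as each one is a reading at a single concentration.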